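Swapping Fluoro for Trifluoromethyl: Tolerance Held at the Limit

The compounds below may be only part of what the source reports. "The series", "measured", "known", "first", "only" and "open" are said of these compounds alone.

Three amides built on a shared core were tested in an ADME assay on MDCK cells (Canis lupus familiaris) for cytotoxicity, read by MTT assay, with a stated time of 72 h; a lower number here means that less compound is tolerated, a higher number that more compound is tolerated. Compound 1 `C=C(CC(=O)Nc1ccc(F)cc1F)C(=O)O` gives > 110000 nM, which is a limit of the assay and not a number. Compound 2 `C=C(CC(=O)Nc1ccc(C(F)(F)F)cc1F)C(=O)O` likewise gives > 110000 nM, again a limit. Compound 3 `C=C(CC(=O)Nc1cc(F)ccc1F)C(=O)O` gives > 110000 nM, also a limit rather than a number. Because of the limit of > 110000 nM in this assay, at which 3 of the 3 values shown sit, the step that the two limits leave unreadable from compound 1 to compound 2 cannot be read, although the change itself is clear: trifluoromethyl in place of fluoro on an aromatic carbon. The cores of compound 1 and compound 3 hold the same atoms joined differently, and the difference between them is not broken down here. Compound 4 `C=C(CC(=O)Nc1cc(C(F)(F)F)ccc1F)C(=O)O` has not yet been measured in this assay; it arises from compound 3 by the same kind of change, (trifluoromethyl in place of fluoro on an aromatic carbon), though the surroundings differ: here the place is meta to a group of 9 heavy atoms and para to a fluoro group, whereas in compound 2 it is meta to a fluoro group and para to a group of 9 heavy atoms. Going by the values given here, since every value so far sits at the limit of > 110000 nM in this assay, at which 3 of the 3 values shown sit, the step from compound 3 is expected to be a step that the limit leaves unreadable from compound 3 to compound 4. Compound 4 is therefore estimated to give 150000 nM.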

Compound 4, half-maximal cytotoxic concentration: > 110000 nM
Compound 4 ended at the assay's limit; the forecaster's own chance of this, stated with the estimate: 85%; the middle value is on the limit's open side.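

No new step can be read from compound 3 to compound 4, because both results are limits and not numbers: the limit of > 110000 nM in this assay, at which 4 of the 4 values shown sit.

The compounds shown leave open what size of change, if any, trifluoromethyl in place of fluoro brings, and at what concentration any of the four compounds would become toxic to these cells.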